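This account rests on a few compounds, and the source may have more. Where it says the series, first, only, none or still open, it means among the compounds named here.

Measured so far in a functional assay on A549 cells (Homo sapiens) for cytotoxicity, read by MTT assay, with a stated time of 72 h; on this read-out lower numbers stand for stronger inhibition and higher numbers for weaker inhibition:

Compound 1, `O=C(N/N=C/c1ccc(O)cc1O)Nc1cc2c(Nc3ccc(F)c(Cl)c3)ncnc2cc1O[C@H]1CCOC1`, gives 9360 nM.
Compound 2, `CCN(CC)c1ccc(/C=N/NC(=O)Nc2cc3c(Nc4ccc(F)c(Cl)c4)ncnc3cc2O[C@H]2CCOC2)c(O)c1`, gives 15700 nM.
Compound 3, `COc1cc2ncnc(Nc3ccc(F)c(Cl)c3)c2cc1NC(=O)N/N=C/c1ccc(O)cc1O`, gives 31400 nM.

Compound 4, `CCN(CC)c1ccc(/C=N/NC(=O)Nc2cc3c(Nc4ccc(F)c(Cl)c4)ncnc3cc2OC)c(O)c1`, has not yet been measured in this assay. It differs from compound 3 by diethylamino in place of hydroxy on an aromatic carbon. The same change has already been made once, from compound 1 to compound 2: diethylamino in place of hydroxy on an aromatic carbon, where it gave a 1.7-fold higher number from compound 1 to compound 2 (0.22 log units; within the scatter). The cores of the two pairs differ by methyl in place of oxolan-3-yl on an oxygen on an aromatic ring, a change that on its own gave a 3.4-fold higher number from compound 1 to compound 3 (0.53 log units; beyond the scatter). The place of the change is described in the same words in both pairs. Resting on the single earlier step, the step from compound 3 to compound 4 is expected to be a 1.5-fold higher number from compound 3 to compound 4 (0.18 log units; within the scatter). Compound 4 is therefore estimated at 48000 nM, with a likely range from 20000 nM to 110000 nM.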

Compound 4, half-maximal inhibitory concentration: 27300 nM
For compound 4 the middle estimate is 1.8-fold (0.25 log units) above the measured one; low and high end bracket the measured number.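

In this assay, diethylamino in place of hydroxy gives a 1.2-fold lower number from compound 3 to compound 4 (0.06 log units; within the scatter), and set beside the earlier step, the change carries across the two cores with no difference that stands out from the scatter: the same change on two cores in this assay, a 1.7-fold higher number (0.22 log units; within the scatter) from compound 1 to compound 2 and a 1.2-fold lower number (0.06 log units; within the scatter) from compound 3 to compound 4, 1.9-fold (0.29 log units) apart, within the scatter of two such steps. Methyl in place of oxolan-3-yl gives a 1.7-fold higher number from compound 2 to compound 4 (0.24 log units; within the scatter), and this step also agrees with its earlier counterpart: the same change on two cores in this assay, a 3.4-fold higher number (0.53 log units; beyond the scatter) from compound 1 to compound 3 and a 1.7-fold higher number (0.24 log units; within the scatter) from compound 2 to compound 4, 1.9-fold (0.29 log units) apart, within the scatter of two such steps. This shows that both changes behaved alike on the two cores, but it does not show that diethylamino moves the number at all, since both of its steps lie within the scatter, and two pairs establish no rule for the series.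

The compounds shown leave open what another amine, such as dimethylamino or morpholine, would do in place of diethylamino. They also leave open whether a longer chain than methyl on the oxygen would give a step beyond the scatter.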